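N-Methylation of the ring amine in two indole sulfone cores

The source may report more compounds than this note shows. Statements on the series, on what has been measured and on what is new or still open speak of the compounds shown alone.

Measured compounds:
compound 1 `COc1ccc2c(c1)c(S(=O)(=O)c1cccc(F)c1)cn2C1CCCNC1`: 10.7 nM
compound 2 `COc1ccc2c(c1)c(S(=O)(=O)c1cccc(F)c1)cn2C1CCCN(C)C1`: 68 nM
compound 3 `O=S(=O)(c1cccc(F)c1)c1cn(C2CCNC2)c2ccccc12`: 4.7 nM

All three values come from an assay on HeLa cells for displacement of a labelled ligand from 5-hydroxytryptamine receptor 6 (Homo sapiens), with a stated time of 2 h; on this read-out higher numbers stand for weaker inhibition and lower numbers for stronger inhibition. Compound 3 gives the lowest number of the three; compound 1 stands nearest to it and compound 2 furthest. The difference between the core of compound 1 and the core of compound 3 is not broken down here.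

Within the core of compound 1 one change is measured: methyl in place of hydrogen on an amine nitrogen in a ring, which gives a 6.4-fold higher number from compound 1 to compound 2 (0.80 log units; beyond the scatter).

Compound 4 `CN1CCC(n2cc(S(=O)(=O)c3cccc(F)c3)c3ccccc32)C1` is not yet measured. It differs from compound 3 by methyl in place of hydrogen on an amine nitrogen in a ring. This is the same kind of change as that from compound 1 to compound 2, but the place differs: in compound 2 the amine nitrogen sits in a six-membered non-aromatic ring with 1 nitrogen, in compound 4 in a five-membered non-aromatic ring with 1 nitrogen; in both it lies two ring bonds from the ring atom that bears a large group.

Resting on the measured step of a 6.4-fold higher number from compound 1 to compound 2 (0.80 log units; beyond the scatter), a weakening of similar size is expected in this assay, so the estimated step is a 6.4-fold higher number from compound 3 to compound 4 (0.81 log units; beyond the scatter). Compound 4 is therefore expected to give about 30 nM, estimated to lie between 12 nM and 75 nM.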

Compound 4, inhibition constant: 3.5 nM
Compound 4: the middle estimate sits 8.6-fold (0.93 log units) above what was measured; measured number below the stated range.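

In this assay methyl in place of hydrogen on the amine nitrogen of the five-membered ring gives a 1.3-fold lower number from compound 3 to compound 4 (0.13 log units; within the scatter) and so shows no measurable penalty on the core of compound 3. The penalty seen on the core of compound 1 therefore does not carry over to the core of compound 3 in this series: the same change on two cores in this assay, a 6.4-fold higher number (0.80 log units; beyond the scatter) from compound 1 to compound 2 and a 1.3-fold lower number (0.13 log units; within the scatter) from compound 3 to compound 4, 8.5-fold (0.93 log units) apart, beyond the scatter of two such steps

Among the compounds shown here, with only one pair on each core, these data do not show which difference between the cores separates the two steps: the size of the amine ring or the methoxy group present only on the core of compound 1.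

The compounds shown leave open how the methyl step behaves on a core carrying only one of those differences, such as the five-membered amine ring together with the methoxy group. They also leave open what an ethyl or acetyl group on the same amine nitrogen would give on either core.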